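Removing the pyrazolecarbonyl cap: expected cytotoxicity of compound 3

The compounds below may be only part of what the source reports. "The series", "measured", "known", "first", "only" and "open" are said of these compounds alone.

The compounds were examined in an ADME assay on CHO cells (Cricetulus griseus) for cytotoxicity; a higher number here means a weaker inhibitor, a lower number a stronger inhibitor. Compound 1 `c1cc(-c2cccc(Nc3cnccn3)n2)cc(N2CCNCC2)c1` gives only a limit in this assay, > 15000 nM. Compound 2 `Cc1cc(C(=O)Nc2cc(Nc3cnccn3)nc(-c3ccnc(N4CCNCC4)c3)c2)n(C)n1` likewise gives only a limit in this assay, > 20000 nM. Both results shown are thus limits rather than numbers. Compound 2 stands at the limit of > 20000 nM in this assay, at which 1 of the 2 values shown sits. Compound 1 sits at the limit of > 15000 nM in this assay, at which 1 of the 2 values shown sits. No measured step connects the two compounds, so the size of any change between them cannot be described from the data shown.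

Compound 3 `Nc1cc(Nc2cnccn2)nc(-c2ccnc(N3CCNCC3)c2)c1` has not yet been measured in this assay. It differs from compound 2 in one place:

hydrogen in place of (1,3-dimethyl-1H-pyrazol-5-yl)carbonyl on a nitrogen on an aromatic ring

With the measured values resting at limits, nothing shown points to a measurable change in this assay when hydrogen replaces the (1,3-dimethyl-1H-pyrazol-5-yl)carbonyl on the nitrogen on the aromatic ring. The step expected is none beyond the scatter: a number no higher from compound 2 to compound 3 (the limit leaves the size open). Compound 3 is therefore estimated to give 20000 nM, within a range from 8000 nM to 50000 nM, and is expected most probably to be reported once more as a limit in this assay.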

Compound 3, half-maximal inhibitory concentration: > 20000 nM
Compound 3 gave a limit, no number (the forecaster's own chance of this, stated with the estimate: 75%); the middle value sits exactly at the limit.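

In this assay compound 3 gives > 20000 nM, which is a limit and not a number. Among the compounds shown here, compound 2 also rests at a limit, so no step between compound 2 and compound 3 can be read. The compounds shown leave open what actual half-maximal inhibitory concentration, if any, each of them has on these cells.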